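The compounds below may be only part of what the source reports. "The series", "measured", "known", "first", "only" and "open" are said of these compounds alone.

For the measured compounds named here, compound 2 `Cc1cc(Nc2cc(Br)cc(OCC(F)(F)F)c2)nc(N)n1` is one of two compounds tested in an assay on cells for inhibition of S-adenosylmethionine decarboxylase proenzyme (Homo sapiens), read by mass spectrometry, at pH 7.2; a higher number here means a weaker inhibitor, a lower number a stronger inhibitor; in that assay compound 2 gives 44000 nM, and this is the only outright number reported for the series. Compound 1 `Cc1cc(Nc2cc(Br)cc(S(F)(F)(F)(F)F)c2)nc(N)n1` was tested alongside it, and compound 1 gives > 180000 nM, which is the limit of > 180000 nM in this assay, at which 1 of the 2 values shown sits, rather than a number. Between these two, the measured step is an at least 4.0-fold lower number from compound 1 to compound 2 (0.61 log units; beyond the scatter). Compound 3 `CCCCOc1cc(Br)cc(Nc2cc(C)nc(N)n2)c1` has not yet been measured in this assay. It differs from compound 2 in one place: propyl in place of trifluoromethyl on a saturated chain carbon bound to an oxygen on an aromatic ring. Going by the values given here, the only measured step, from compound 1 to compound 2, exchanges the whole group on the aromatic carbon, whereas the change to compound 3 keeps the oxygen link and alters only the far end of the chain; no measured step shows what such an exchange does here, so the guide is weak. The step is therefore expected to be a 1.1-fold lower number from compound 2 to compound 3 (0.04 log units; within the scatter), that is, no change beyond the scatter. Compound 3 is estimated at 40000 nM, with a range from 12000 nM to 130000 nM.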

Compound 3, half-maximal inhibitory concentration: > 180000 nM
Compound 3: only a limit was reported; the forecaster's own chance of this, stated with the estimate: 15%; at least 4.5-fold (0.65 log units) between middle value and limit.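

In this assay, the change from 2,2,2-trifluoroethoxy to butoxy gives an at least 4.0-fold higher number from compound 2 to compound 3 (0.61 log units; beyond the scatter). This is the first sign that the far end of the chain matters at this position: keeping the oxygen link on the aromatic ring does not by itself preserve a measurable number, and among the compounds shown, only compound 2, with its trifluoromethyl end, gives one. Compound 3 and compound 1 both stop at a limit of the assay rather than a number, so the step between them cannot be read, and neither compound can be ranked against the other: the limit of > 180000 nM in this assay, at which 2 of the 3 values shown sit.

This single change both lengthens the chain and removes the fluorine atoms, so the compounds shown cannot say which of the two goes with the weaker result. A plain ethoxy group would separate those two effects, while a chain ending in an amine or a carboxylic acid would show whether anything other than trifluoromethyl at the far end can give a number below the limit.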